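A side-group swap at compound 2

The source may hold more compounds than are shown below. What is called first, only, known or untested is meant among the compounds shown, and "the series" means these compounds.

Measured so far in a functional assay on MCF7 cells (Homo sapiens) for cytotoxicity, read by sulforhodamine B assay, with a stated time of 72 h; on this read-out higher numbers stand for weaker inhibition and lower numbers for stronger inhibition:
- compound 1 `O=C(Nc1ccc(Nc2ncnc3c2cnn3-c2ccccc2)cc1)Nc1cccc(Br)c1`: 36300 nM
- compound 2 `Cc1ccccc1NC(=O)Nc1ccc(Nc2ncnc3c2cnn3-c2ccc(Cl)cc2)cc1`: 3150 nM
- compound 3 `O=C(Nc1ccc(Cl)c(C(F)(F)F)c1)c1ccc(Nc2ncnc3c2cnn3-c2ccccc2)cc1`: 75900 nM

Among these three, compound 2 has the lowest number, and so the strongest inhibition. Its distance to each of the other two lies beyond the usual scatter of repeated measurements.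

Compound 4 `O=C(Nc1ccccc1Cl)c1ccc(Nc2ncnc3c2cnn3-c2ccc(Cl)cc2)cc1` has not yet been measured. Compared with compound 2, it has (2-chlorophenyl)carbamoyl in place of ((2-methylphenyl)carbamoyl)amino on an aromatic carbon. The rest of the structure stays the same.

For the measured compounds named here, no measured pair here isolates this change, so the evidence is thin. Compound 3, at 75900 nM, has a carbamoyl link like compound 4, and its number is higher than that of compound 1, at 36300 nM, whose link resembles that of compound 2. However, compound 1 and compound 3 also differ elsewhere, so this is only a weak hint. It points towards a higher number in this assay, meaning weaker inhibition, with a modest step beyond the scatter. The expected step is a 3.8-fold higher number from compound 2 to compound 4 (0.58 log units; beyond the scatter).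

For compound 4, the estimated value is 12000 nM, with an expected range from 3000 nM to 48000 nM.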

Compound 4, half-maximal inhibitory concentration: > 100000 nM
Compound 4: only a limit was reported; the forecaster's own chance of this, stated with the estimate: 10%; middle value at least 8.3-fold (0.92 log units) from the limit.
By their numbers in this assay, from the lowest: compound 2; then compound 1; then compound 3. At a limit, above all of these: compound 4.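

In this assay, compound 4 is reported only as a limit, > 100000 nM. Replacing ((2-methylphenyl)carbamoyl)amino with (2-chlorophenyl)carbamoyl on the aromatic carbon para to a large group gives an at least 31-fold higher number from compound 2 to compound 4 (1.50 log units; beyond the scatter). This is the only comparison among the compounds shown in which the rest of the structure stays the same, and it shows that the read-out in these cells depends strongly on what sits at this place, though the true size of the step stays open, as the reading ends at a limit: the limit of > 100000 nM in this assay, at which 1 of the 4 values shown sits.

The swap alters two things at once: the group goes from 2 hydrogen-bond donors to 1 as its link changes, and the ring changes from 2-methylphenyl to 2-chlorophenyl, so the compounds shown leave open which of these changes matters. Also open, on these data alone, is how a sulfonamide link or a 2-methoxyphenyl ring would read at this place, which could help to separate the role of the link from the role of the group on the ring.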